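Oxygen and sulfur cores with ortho-halophenoxy chains

A few compounds are considered here, and "the series" means these few. Any claim that something is new, unique, unknown or untested is made for them only; others in the source may bear on it.

Measured compounds:
compound 1 `NC1=NC2(CCOCC2)N(OCCCOc2ccccc2Cl)C(N)=N1`: 1750 nM
compound 2 `NC1=NC2(CCOCC2)N(OCCCOc2ccccc2Br)C(N)=N1`: 860 nM
compound 3 `NC1=NC2(CCSCC2)N(OCCCOc2ccccc2Br)C(N)=N1`: 90 nM

All three were run in a functional assay on HepG2 cells (Homo sapiens) for antiproliferative activity, read by MTT assay, with a stated time of 72 h; on this read-out lower numbers stand for stronger inhibition and higher numbers for weaker inhibition. Compound 3 gives the lowest number in this assay; its nearest neighbour is compound 2, and compound 1 stands furthest away. How the core of compound 3 differs from the core of compound 2 is not broken down here.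

One change appears twice in the set. Between the measured pair it reads (chloro in place of bromo on an aromatic carbon), and it gave a 2.0-fold higher number from compound 2 to compound 1 (0.31 log units; beyond the scatter). The same change, (chloro in place of bromo on an aromatic carbon), leads from compound 3 to the unmeasured compound 4 `NC1=NC2(CCSCC2)N(OCCCOc2ccccc2Cl)C(N)=N1`. The place of the change is described in the same words both times, so it is taken as the same change on a different core.

For compound 4 a step of about a 2.0-fold higher number from compound 3 to compound 4 (0.30 log units; within the scatter) in this assay is expected, resting on the measured step from compound 2 to compound 1. Compound 4 is therefore estimated at 180 nM, with a likely range from 90 nM to 360 nM.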

Compound 4, half-maximal inhibitory concentration: 80 nM
Compound 4: the middle estimate sits 2.3-fold (0.35 log units) above what was measured; the whole stated range lies above it.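

In this assay, chloro in place of bromo on the core of compound 3 gives a 1.1-fold lower number from compound 3 to compound 4 (0.05 log units; within the scatter). Set beside the same change on the core of compound 2, this step does not differ from the earlier one by more than the scatter of two such steps: the same change on two cores in this assay, a 2.0-fold higher number (0.31 log units; beyond the scatter) from compound 2 to compound 1 and a 1.1-fold lower number (0.05 log units; within the scatter) from compound 3 to compound 4, 2.3-fold (0.36 log units) apart, within the scatter of two such steps. The change can therefore be carried between these two cores with no measurable dependence on the core, but two pairs cannot fix the size of the step or show that it would hold on any other core.

Open, on these data alone, are other groups at this place, such as fluoro, methoxy or nitrile. Also open, as far as these compounds go, are a longer chain and a core carrying an amine.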